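Adding a hydroxy group to compound 2

A few compounds are considered here, and "the series" means these few. Any claim that something is new, unique, unknown or untested is made for them only; others in the source may bear on it.

In a toxicity assay on MRC5 cells (Homo sapiens) for inhibition, read by MTT assay, with a stated time of 72 h (a lower number here means a stronger inhibitor, a higher number a weaker inhibitor), compound 1 (`CCCC(=O)OCCc1ccc(O)c(O)c1`) gives 71500 nM and compound 2 (`CCCCCCCCCCCC(=O)OCCc1ccc(O)cc1`) gives 67200 nM so that the two values sit within the scatter of each other. Compound 3 (`CCCCCCCCCCCC(=O)OCCc1ccc(O)c(O)c1`) differs from compound 2 by hydroxy in place of hydrogen on an aromatic carbon with hydroxy in place of hydrogen on an aromatic carbon, reading 4-hydroxyphenyl to 3,4-dihydroxyphenyl. Going by the values given here, no measured pair isolates this change, so the expectation remains tentative. A moderate move towards a stronger inhibitor is expected in this assay with a 1.9-fold lower number from compound 2 to compound 3 (0.28 log units; within the scatter) as the estimated step. Compound 3 is estimated at 35000 nM with an expected range from 12000 nM to 90000 nM in this series.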

Compound 3, half-maximal inhibitory concentration: 38100 nM
Compound 3: the middle estimate sits 1.1-fold (0.04 log units) below what was measured; the range from low to high includes it.
By their numbers in this assay, from the lowest: compounds 3, 2 and 1 (each within the scatter of the next).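

In this assay, hydroxy in place of hydrogen on an aromatic carbon, ortho to a hydroxy group, now has a measured pair, with a 1.8-fold lower number from compound 2 to compound 3 (0.25 log units; within the scatter), so this change at this position stays inside the scatter here. Octyl in place of hydrogen on a saturated chain carbon, three bonds along the chain from a carbonyl carbon, also has a measured pair, with a 1.9-fold lower number from compound 1 to compound 3 (0.27 log units; within the scatter), and likewise stays inside the scatter. No supporting data bear on these readings.

From the compounds shown here alone, whether methoxy in place of the added hydroxy, an amine, or a chain longer than that of compound 3 would give a step beyond the scatter remains open.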